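This account rests on a few compounds, and the source may have more. Where it says the series, first, only, none or still open, it means among the compounds named here.

In an assay on isolated protein for displacement of a labelled ligand from 5-hydroxytryptamine receptor 6 (Homo sapiens) (on this read-out lower numbers stand for stronger inhibition and higher numbers for weaker inhibition), compound 3 `CN(CC(N)=O)C[C@@H]1CCCc2cc(S(=O)(=O)c3cccc(F)c3)ccc21` gives 1.26 nM, the second highest of three numbers: compound 2 `O=S(=O)(c1cccc(F)c1)c1ccc2c(c1)CCC[C@H]2CN1CC(O)C1` gives 0.1 nM, and compound 1 `O=S(=O)(c1cccc(F)c1)c1ccc2c(c1)CCC[C@H]2CN1CCCS1(=O)=O` gives 31.6 nM. Compound 4 `NCC(=O)NC[C@@H]1CCCc2cc(S(=O)(=O)c3cccc(F)c3)ccc21` differs from compound 3 by ((aminomethyl)carbonyl)amino in place of (carbamoylmethyl)(methyl)amino on a saturated chain carbon bound to a saturated ring carbon. All three measured steps alter the group at this same place: a 320-fold lower number from compound 1 to compound 2 (2.50 log units; beyond the scatter), a 25-fold lower number from compound 1 to compound 3 (1.40 log units; beyond the scatter) and a 13-fold higher number from compound 2 to compound 3 (1.10 log units; beyond the scatter). This position has thus shifted the number strongly in both directions. Going by the values given here, neither the group that leaves nor the one that enters in compound 4 appears elsewhere among the measured compounds, and the direction of the change stays open. A step of moderate size is expected, a 2.4-fold higher number from compound 3 to compound 4 (0.38 log units; beyond the scatter). For compound 4 the estimate is 3 nM, with a range from 0.8 nM to 12 nM.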

Compound 4, inhibition constant: 0.316 nM
Compound 4: the middle estimate sits 9.5-fold (0.98 log units) above what was measured; measured number below the stated range.
By their numbers in this assay, from the lowest: compound 2; then compound 4; then compound 3; then compound 1.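

Replacing (carbamoylmethyl)(methyl)amino with ((aminomethyl)carbonyl)amino, both open chains with no ring, still moves the number in this assay, giving a 4.0-fold lower number from compound 3 to compound 4 (0.60 log units; beyond the scatter). So this position responds to a change between two chains, not only to a change involving a ring. The new chain does not reach the ring-bearing 3-hydroxyazetidin-1-yl, with a 3.2-fold higher number from compound 2 to compound 4 (0.50 log units; beyond the scatter), but the large 100-fold lower number from compound 1 to compound 4 (2.00 log units; beyond the scatter) shows how far it stands from the weakest group at this place.

Nothing available explains this change. The compounds shown leave open how a carboxylic acid in place of the end amine, or a longer chain carrying that amine, would read.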